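Swapping a Methoxyphenyl Amide for a Dimethylthiazolyl Amide

The compounds below may be only part of what the source reports. "The series", "measured", "known", "first", "only" and "open" are said of these compounds alone.

Compound 3 `COc1cccc(NC(=O)COc2cc(C)nc3ccc(OC)cc23)c1` was tested in a toxicity assay on HepG2 cells (Homo sapiens) for inhibition, read by CellTiter-Glo, with a stated time of 48 h; a higher number here means a weaker inhibitor, a lower number a stronger inhibitor. Compound 3 gave > 100000 nM, which is a limit of the assay rather than a number. Compound 1 `Cc1cc(C)cc(NC(=O)COc2cc(C)nc3ccc(C(F)(F)F)cc23)c1` likewise gave > 100000 nM, a limit. Compound 2 `Cc1cc(C)cc(NC(=O)COc2cc(C)nc3ccc(OC(F)(F)F)cc23)c1` gave > 100000 nM, also a limit. Among the compounds with values here, the single measured step, a step that the two limits leave unreadable from compound 1 to compound 2, therefore cannot be read. All three values sit at the limit of > 100000 nM in this assay, at which 3 of the 3 values shown sit. Compound 4 `COc1ccc2nc(C)cc(OCC(=O)Nc3nc(C)c(C)s3)c2c1` differs from compound 3 by 4,5-dimethyl-1,3-thiazol-2-yl in place of 3-methoxyphenyl on an amide-type nitrogen. Within the data shown here, no measured step touches this change, and the one step available shows no readable size, so no change beyond the scatter is expected in this assay. Compound 4 is expected to give 100000 nM, estimated between 30000 nM and 300000 nM. The estimated step of a number no higher from compound 3 to compound 4 (the limit leaves the size open) is expected to lie within the scatter.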

Compound 4, half-maximal inhibitory concentration: > 100000 nM
Compound 4 gave a limit, no number (the forecaster's own chance of this, stated with the estimate: 80%); the middle value sits exactly at the limit.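

Compound 3 and compound 4 both give a limit of the assay rather than a number, so the step between them cannot be read: the limit of > 100000 nM in this assay, at which 4 of the 4 values shown sit.

The compounds shown leave open whether any of these group changes alters the result in this assay at all.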